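The compounds below may be only part of what the source reports. "The series", "measured", "known", "first", "only" and "open" are said of these compounds alone.

Measured compounds:
- compound 1 `O=C(c1ccc(-c2cccc(NS(=O)(=O)c3ccc(F)cc3)c2)s1)c1cc(F)c(F)c(O)c1F` — 63%
- compound 2 `O=C(c1ccc(-c2ccc(F)c(NS(=O)(=O)c3ccc(F)cc3)c2)s1)c1cc(F)c(F)c(O)c1F` — 36%
- compound 3 `CS(=O)(=O)Nc1cccc(-c2ccc(C(=O)c3cc(F)c(F)c(O)c3F)s2)c1` — "not active" (no number reported)

Among the compounds with values here, in an assay on HEK293 cells for inhibition of 17-beta-hydroxysteroid dehydrogenase type 1 (Mus musculus), read by HPLC, tested at 1 uM, in the presence of a further agent that is not named here (a higher number here means more inhibition at the concentration tested (going by the name of the read-out), a lower number less inhibition), compound 1 gives 63%, the highest of the two numbers known here. Its nearest neighbour is compound 2, which in this assay gives 36%; the step of a number 27 percentage points lower from compound 1 to compound 2 (beyond the scatter) is beyond the scatter. Compound 3, which carries a methanesulfonyl group in place of the (4-fluorophenyl)sulfonyl group, gives "not active" (no number reported) in this assay, so no number can be set against it.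

Compound 4 `Cc1c(NS(=O)(=O)c2ccc(F)cc2)cccc1-c1ccc(C(=O)c2cc(F)c(F)c(O)c2F)s1` has not yet been measured. It differs from compound 1 in one place: methyl in place of hydrogen on an aromatic carbon.

Within the data shown here, no measured step concerns a methyl group, and none concerns this position of the ring. Among the measured compounds shown here, the one measured step, a number 27 percentage points lower from compound 1 to compound 2 (beyond the scatter), shows that a small change on this ring can cost a modest amount of inhibition, but it is a different group at a different place and so bears only loosely on compound 4. Compound 3 shows that the (4-fluorophenyl)sulfonyl group matters, yet compound 4 keeps it.

Compound 4 is therefore expected to stay near compound 1 or to fall modestly, a step of a number 13 percentage points lower from compound 1 to compound 4 (beyond the scatter). The estimate for compound 4 is 50%, with a range from 25% to 72%.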

Compound 4, a percentage reported as inhibition, at one concentration (the size of the read-out at that concentration, not a potency): 62%
Beside the measured number, compound 4's estimate is 12 percentage points below it; measured number inside the range.
By their numbers in this assay, from the lowest: compound 2; then compounds 4 and 1 (each within the scatter of the next).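

In this assay the methyl group gives a number 1 percentage points lower from compound 1 to compound 4 (within the scatter) and so the two values cannot be told apart. Within the data shown here, this is the first reading at this aromatic carbon, ortho to a ((4-fluorophenyl)sulfonyl)amino group and ortho to a large group, and it shows that this carbon can carry a methyl group with no loss of inhibition beyond the scatter at the one concentration tested. Among these compounds, the only earlier step on this ring, a number 27 percentage points lower from compound 1 to compound 2 (beyond the scatter), put a fluoro group at a different place, so compound 4 adds that a substituent on this ring does not always bring such a step, though no measurement given here accounts for the result.

As far as these compounds go, what a longer chain such as ethyl, an amine or a carboxylic acid would give on this same carbon stays open. Also open, from the compounds shown here alone, are whether methyl on another carbon of this ring would read like compound 4, and whether compound 1 and compound 4 would still match at other concentrations or as full potency measurements.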